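Chlorobenzyl ether isomers and tolerance in Huh-5-2 cells

A few compounds are considered here, and "the series" means these few. Any claim that something is new, unique, unknown or untested is made for them only; others in the source may bear on it.

Measured so far:
compound 1, `O=c1c(OCc2ccccc2Cl)c(-c2ccccc2)oc2cc(O)cc(O)c12`: > 100000 nM
compound 2, `Cc1cccc(COc2c(-c3ccccc3)oc3cc(O)cc(O)c3c2=O)c1`: 29000 nM

Compound 1 is the ether of the shared core carrying the 2-chlorobenzyl group. In an ADME assay on Huh-5-2 cells (Homo sapiens) for cytotoxicity, read by WST assay, with a stated time of 3 days (a higher number here means that more compound is tolerated, a lower number that less compound is tolerated), compound 1 reaches only a limit, > 100000 nM, so its number is not known. Compound 2 carries 3-methylphenyl in place of 2-chlorophenyl on the saturated chain carbon bound to an oxygen on the aromatic ring, and in this assay compound 2 gives 29000 nM. Within the data shown here, the one measured step is an at least 3.4-fold lower number from compound 1 to compound 2 (0.53 log units; beyond the scatter), and it rests on the fact that the limit of > 100000 nM in this assay, at which 1 of the 2 values shown sits, is where compound 1 stands.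

Compound 3 is `O=c1c(OCc2ccc(Cl)cc2)c(-c2ccccc2)oc2cc(O)cc(O)c12`. Its change from compound 1 is 4-chlorophenyl in place of 2-chlorophenyl on a saturated chain carbon bound to an oxygen on an aromatic ring. Among the measured compounds shown here, no measured step moves the chlorine within the ring; the only comparison available, from compound 1 to compound 2, exchanges the whole group. With compound 1 at a limit, the step from it to compound 3 is expected to be small or absent, an at least 1.4-fold lower number from compound 1 to compound 3 (0.15 log units; that floor lies within the scatter). Compound 3 is therefore estimated at 70000 nM, within 25000 nM to 150000 nM, with a fair chance that the assay again returns only a limit.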

Compound 3, half-maximal cytotoxic concentration: 36000 nM
Estimate against measurement, compound 3: 1.9-fold (0.29 log units) above; the measured number falls inside the stated range.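

Moving the chlorine alone, from 2-chlorophenyl to 4-chlorophenyl on the saturated chain carbon bound to an oxygen on an aromatic ring, is enough to shift the number in this assay, giving an at least 2.7-fold lower number from compound 1 to compound 3 (0.44 log units; beyond the scatter), with the same atoms joined differently. The step seen earlier therefore does not require exchanging the chlorine for a methyl group: compound 2 and compound 3 stand together, with a 1.2-fold higher number from compound 2 to compound 3 (0.09 log units; within the scatter), and only compound 1 stands apart from them. Going by these compounds, the true size of the shift remains unknown, and what separates compound 1 from the other two is a limit, not a number: the limit of > 100000 nM in this assay, at which 1 of the 3 values shown sits.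

Still open, on these data alone, is whether the high tolerance of compound 1 belongs to chlorine at that ring position specifically or would also appear with another group there, such as methoxy, fluorine or a carboxylic acid. As far as these compounds go, it is also open whether a longer chain between the oxygen and the ring would keep the difference between 2-chlorophenyl and 4-chlorophenyl in this assay or remove it.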